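Chloro for hydrogen on the pendant phenyl of compound 1

This account rests on a few compounds, and the source may have more. Where it says the series, first, only, none or still open, it means among the compounds named here.

Compound 1 `N#CC1=C(N)N(c2ccc(S(N)(=O)=O)cc2)C2=C(CCCC2)C1c1ccccc1` is the weakest of the three measured compounds in a functional assay on Ehrlich cells (Mus musculus) for cytotoxicity, read by trypan blue exclusion, with a stated time of 2 h, tested at 50 ug/mL (a lower number here means a weaker effect, a higher number a stronger effect of the compound at the concentration tested), where compound 1 gives 20%. Compound 2 `N#CC1=C(N)N(c2ccc(S(N)(=O)=O)cc2)C2=C(CCCC2)C1c1ccccc1O` gives 50% and compound 3 `N#CC1=C(N)N(c2ccc(S(N)(=O)=O)cc2)C2=C(CCCC2)C1c1ccc(O)cc1` gives 60%; the steps of a number 30 percentage points higher from compound 1 to compound 2 (beyond the scatter) and a number 40 percentage points higher from compound 1 to compound 3 (beyond the scatter) both lie beyond the scatter, while a number 10 percentage points higher from compound 2 to compound 3 (within the scatter) does not. Compound 4 `N#CC1=C(N)N(c2ccc(S(N)(=O)=O)cc2)C2=C(CCCC2)C1c1ccccc1Cl` differs from compound 1 by chloro in place of hydrogen on an aromatic carbon, so the phenyl becomes a 2-chlorophenyl. The two measured steps from compound 1 both add a hydroxy, which brings hydrogen-bond donors and acceptors that chloro lacks, so they bear on this step only in showing that a substituent on that ring raised the read-out. Compound 4 is therefore expected to show a modest rise, a number 15 percentage points higher from compound 1 to compound 4 (beyond the scatter), giving an estimated 35% with a range from 15% to 60%.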

Compound 4, a percentage reported as activity, at one concentration (the size of the read-out at that concentration, not a potency): 5%
Compound 4: middle estimate off by 30 percentage points, on the high side; measured number outside the range, below it.
By their numbers in this assay, from the lowest: compound 4; then compound 1; then compounds 2 and 3 (each within the scatter of the next).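

In this assay, for the compounds shown here, a substituent on this phenyl does not always raise the read-out: chloro brings the only downward step from compound 1 (a number 15 percentage points lower from compound 1 to compound 4 (beyond the scatter)), so the direction depends on the group that enters. On the same aromatic carbon, hydroxy and chloro part widely (a number 45 percentage points lower from compound 2 to compound 4 (beyond the scatter)), and the gap is also large for 2-chlorophenyl in place of 4-hydroxyphenyl (a number 55 percentage points lower from compound 3 to compound 4 (beyond the scatter)). Nothing measured here explains the drop.

On these data alone, whether a methoxy or an amine on that carbon would follow chloro or hydroxy stays open. So does the outcome of chloro on the carbon carrying the hydroxy of compound 3.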